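Weak Antagonists: Swapping a Branched Chain for Fluorobenzyl

This account rests on a few compounds, and the source may have more. Where it says the series, first, only, none or still open, it means among the compounds named here.

In a functional assay on CHO cells for antagonist activity at adenosine receptor A2b (Homo sapiens) (on this read-out higher numbers stand for weaker inhibition and lower numbers for stronger inhibition), compound 1 `O=C(Nc1ncc(C(=O)O)c2nc(-c3ccco3)nn12)NC1CCCCC1` gives only a limit of the assay, > 30000 nM. Compound 2 `CCCCC(CC)CNc1ncc(C(=O)O)c2nc(-c3ccco3)nn12` likewise gives only a limit of the assay, > 10000 nM. The step that the two limits leave unreadable from compound 1 to compound 2 is unreadable, and compound 2 stands among values that are limits alone. Compound 3 `O=C(O)c1cnc(NCc2ccc(F)cc2)n2nc(-c3ccco3)nc12` differs from compound 2 by 4-fluorophenyl in place of 1-ethylpentyl on a saturated chain carbon bound to a nitrogen on an aromatic ring. Within the data shown here, the one measured step cannot be read, so no measured step informs this change. Compound 3 is expected to remain near the edge of detection, with an estimated step that the limit leaves unreadable from compound 2 to compound 3. The estimate for compound 3 is 15000 nM, ranging from 2000 nM to 100000 nM.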

Compound 3, inhibition constant: > 30000 nM
Compound 3 ended at the assay's limit; the forecaster's own chance of this, stated with the estimate: 60%; at least 2.0-fold (0.30 log units) between middle value and limit.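

Among these compounds, compound 1, compound 2 and compound 3 all give only limits of the assay, so no step among them can be read. From the compounds shown here alone, how strongly each inhibits the receptor, and whether 2-ethylhexyl and 4-fluorobenzyl differ at all, stays open.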